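This account rests on a few compounds, and the source may have more. Where it says the series, first, only, none or still open, it means among the compounds named here.

For the measured compounds named here, the three compounds measured so far share one core and differ only in the group on the carbonyl carbon of the amide. Compound 1 `COc1ccc(CN(C(C)=O)c2cc(OC)c(OC)c(OC)c2)cc1O` gives 270 nM in a functional assay on HCT-116 cells (Homo sapiens) for inhibition, read by MTT assay, with a stated time of 48 h; a lower number here means a stronger inhibitor, a higher number a weaker inhibitor. Compound 2 `CCC(=O)N(Cc1ccc(OC)c(O)c1)c1cc(OC)c(OC)c(OC)c1` gives 61 nM. Compound 3 `COc1ccc(CN(C(=O)CCl)c2cc(OC)c(OC)c(OC)c2)cc1O` gives 250 nM, which places it second highest of the three: its nearest neighbour is compound 1, a gap within the scatter, and the furthest is compound 2, with a 4.1-fold higher number from compound 2 to compound 3 (0.61 log units; beyond the scatter).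

The next compound, compound 4 `COc1ccc(CN(C(=O)C(C)C)c2cc(OC)c(OC)c(OC)c2)cc1O`, differs from compound 3 by isopropyl in place of chloromethyl on a carbonyl carbon.

Going by the values given here, two measured steps bear on this change. Replacing hydrogen with methyl at that chain carbon gave a 4.4-fold lower number from compound 1 to compound 2 (0.65 log units; beyond the scatter), and replacing methyl with chloro gave a 4.1-fold higher number from compound 2 to compound 3 (0.61 log units; beyond the scatter). An isopropyl group here is a larger branched alkyl than the methyl of compound 2, so a modest drop in number from compound 3 is expected, a 3.6-fold lower number from compound 3 to compound 4 (0.55 log units; beyond the scatter), landing near where compound 2 stands. Compound 4 is therefore estimated at 70 nM, with a range of 25 nM to 200 nM.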

Compound 4, half-maximal inhibitory concentration: 310 nM
For compound 4 the middle estimate is 4.4-fold (0.65 log units) below the measured one; measured number above the stated range.
By their numbers in this assay, from the lowest: compound 2; then compounds 3, 1 and 4 (each within the scatter of the next).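

Adding methyl in place of hydrogen on the saturated chain carbon bound to the carbonyl carbon helped once but not a second time: the gain seen in compound 2 is lost, with a 5.1-fold higher number from compound 2 to compound 4 (0.71 log units; beyond the scatter). Isopropyl on the carbonyl carbon cannot be told apart from chloromethyl, with a 1.2-fold higher number from compound 3 to compound 4 (0.09 log units; within the scatter), or from methyl, with a 1.1-fold higher number from compound 1 to compound 4 (0.06 log units; within the scatter), so among these four compounds the number does not follow group size in one direction, and only compound 2 stands apart. Nothing available explains why this position behaves in this way.

As far as these compounds go, it remains open whether a longer straight chain, such as butyl, would keep the number of compound 2 or lose it as isopropyl does. A cyclopropyl ring or a methoxymethyl group on the carbonyl carbon would also test how narrow this preference is.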